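This account rests on a few compounds, and the source may have more. Where it says the series, first, only, none or still open, it means among the compounds named here.

In a functional assay on A549 cells (Homo sapiens) for antiproliferative activity, read by MTT assay, with a stated time of 48 h (a higher number here means a weaker inhibitor, a lower number a stronger inhibitor), compound 2 `COc1ccc(N/C=C\C(=O)c2cn(-c3ccccc3)nc2-c2ccccc2)cc1` gives 3250 nM. Among the compounds with values here, only one other number exists, and compound 1 `O=C(/C=C\Nc1ccc(O)cc1)c1cn(-c2ccccc2)nc1-c1ccccc1` with 3210 nM cannot be told apart from it, as the step of a 1.0-fold higher number from compound 1 to compound 2 (0.01 log units; within the scatter) shows. Compound 3 `COc1ccc(N/C=C\C(=O)c2cn(-c3ccccc3)nc2-c2ccc(F)cc2)cc1` differs from compound 2 by fluoro in place of hydrogen on an aromatic carbon, read one bond further out as phenyl to 4-fluorophenyl. Within the data shown here, the single measured step concerns a different ring and a different group, so no step bears on this change, and nothing in the data argues for a shift beyond the scatter. Compound 3 is therefore expected to change little, an estimated step of a 1.1-fold lower number from compound 2 to compound 3 (0.03 log units; within the scatter) in this assay. For compound 3 the expected value is 3000 nM, with a range from 1400 nM to 6500 nM.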

Compound 3, half-maximal inhibitory concentration: 8900 nM
The estimate for compound 3 lay 3.0-fold (0.47 log units) below the measured number; measured number outside the range, above it.
By their numbers in this assay, from the lowest: compounds 1 and 2 (each within the scatter of the next); then compound 3.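

In this assay, the change from phenyl to 4-fluorophenyl is not a silent swap: it gives a 2.7-fold higher number from compound 2 to compound 3 (0.44 log units; beyond the scatter), a modest loss of strength. Within the data shown here, this ring position therefore responds to a single added atom, whereas the only earlier step, on a different ring, stayed within the scatter. Nothing available here explains the shift. A single step cannot show whether this loss is specific to fluoro or appears with any group at this place. Chloro, methyl or an amine at the same place would help separate those possibilities.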